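Aryl replacement at the saturated ring carbon

The source may report more compounds than this note shows. Statements on the series, on what has been measured and on what is new or still open speak of the compounds shown alone.

Measured so far:
compound 1 `COC(=O)C1=C(C)N=C(C)/C(=C(\O)OC)C1c1c(F)c(F)c(F)c(F)c1F` — 4.37 nM
compound 2 `COC(=O)C1=C(C)N=C(C)/C(=C(\O)OC)C1c1ccccc1I` — 46.8 nM

In a functional assay (muscle tissue) with Cavia porcellus as the target (a higher number here means that more compound is needed for the effect, a lower number that less compound is needed), compound 2 gives 46.8 nM, the highest of the two numbers. Compound 1 gives 4.37 nM in this assay, a lower number by a gap beyond the usual scatter. Within the data shown here, no two measured compounds differ in a single place, so no step has been computed.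

Compound 3 `COC(=O)C1=C(C)N=C(C)/C(=C(\O)OC)C1c1cccc(Cl)c1Cl` has not been measured. It differs from compound 2 as follows: 2,3-dichlorophenyl in place of 2-iodophenyl on a saturated ring carbon.

Both measured compounds carry a halogenated phenyl at this position, and compound 1, with the more heavily halogenated ring, gives the lower number 4.37 nM. A step toward a lower number, of moderate size and likely beyond the scatter, is therefore expected, as a 4.7-fold lower number from compound 2 to compound 3 (0.67 log units; beyond the scatter). For compound 3 the estimate in this assay is 10 nM, with a range from 2.5 nM to 40 nM.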

Compound 3, half-maximal effective concentration: 19.1 nM
For compound 3 the middle estimate is 1.9-fold (0.28 log units) below the measured one; the measured number falls inside the stated range.
By their numbers in this assay, from the lowest: compound 1; then compound 3; then compound 2.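

In this assay, among these compounds, this step gives the first single-place comparison at the saturated ring carbon: 2,3-dichlorophenyl in place of 2-iodophenyl gives a 2.5-fold lower number from compound 2 to compound 3 (0.39 log units; beyond the scatter), a modest step. The number therefore moves with an exchange of halogens alone, while the six-membered carbon aromatic ring, the zero hydrogen-bond donor and acceptor counts, and the absence of net charge stay the same. Nothing measured here bears on why the number moves.

The change swaps iodine for chlorine and adds a second halogen at once, so these two contributions cannot be separated without a phenyl ring bearing a single chlorine. Also open, on these data alone, is how an unsubstituted phenyl, or a phenyl carrying a nitro or methoxy group, would read at this position.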